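Notes on the ether substituent of the shared core

A few compounds are considered here, and "the series" means these few. Any claim that something is new, unique, unknown or untested is made for them only; others in the source may bear on it.

Measured so far, in a functional assay on HEK293 cells for agonist activity at G-protein coupled receptor 39 (Homo sapiens), read by scintillation proximity assay and inositol phosphate accumulation, with a stated time of 75 min, in the presence of a further agent that is not named here; a higher number here means that more compound is needed for the effect, a lower number that less compound is needed:
compound 1 `Cc1cc(C)n(CCOC2CC(=O)Nc3c2c(C)nn3-c2ncnc3nc[nH]c23)n1` gives 16 nM;
compound 2 `Cc1noc(C)c1COC1CC(=O)Nc2c1c(C)nn2-c1ncnc2nc[nH]c12` gives 5 nM;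
compound 3 `Cc1nn(-c2ncnc3nc[nH]c23)c2c1C(OCc1ccc(C#N)cc1)CC(=O)N2` gives 4 nM.

Compound 3 holds the lowest of the three numbers. Its nearest neighbour is compound 2, a 1.3-fold lower number from compound 2 to compound 3 (0.10 log units; within the scatter), while compound 1 is furthest off, a 4.0-fold lower number from compound 1 to compound 3 (0.60 log units; beyond the scatter). Compound 4 `Cc1nn(-c2ncnc3nc[nH]c23)c2c1C(OCc1cc(F)cc3c1OCOC3)CC(=O)N2` differs from compound 3 by a group of 11 heavy atoms (8 carbon, 2 oxygen, 1 fluorine; one six-membered non-aromatic ring with 2 hetero atoms, one six-membered aromatic ring of carbon only) in place of a group of 8 heavy atoms (7 carbon, 1 nitrogen; one six-membered aromatic ring of carbon only), on a saturated chain carbon bound to an oxygen on a saturated carbon. For the measured compounds named here, no measured step swaps one aromatic group for another at this place; a 3.2-fold lower number from compound 1 to compound 2 (0.51 log units; beyond the scatter) and a 4.0-fold lower number from compound 1 to compound 3 (0.60 log units; beyond the scatter) only show that two different groups here give lower numbers than the (3,5-dimethyl-1H-pyrazol-1-yl)methyl group, and a 1.3-fold lower number from compound 2 to compound 3 (0.10 log units; within the scatter) shows the two aromatic groups close together. Little movement is therefore expected. The expected step, small on this reading, is a 1.5-fold higher number from compound 3 to compound 4 (0.18 log units; within the scatter). The estimate for compound 4 in this assay is 6 nM, range 2 nM to 20 nM.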

Compound 4, half-maximal effective concentration: 1.5 nM
Estimate against measurement, compound 4: 4.0-fold (0.60 log units) above; the measured number lies below the stated range.
By their numbers in this assay, from the lowest: compound 4; then compounds 3 and 2 (each within the scatter of the next); then compound 1.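

At this place the group of 11 heavy atoms stands apart from both aromatic groups that had stayed close together (a 2.7-fold lower number from compound 3 to compound 4 (0.43 log units; beyond the scatter)) (a 3.3-fold lower number from compound 2 to compound 4 (0.52 log units; beyond the scatter)). Its step away from the (3,5-dimethyl-1H-pyrazol-1-yl)methyl group is the only large one in the series (an 11-fold lower number from compound 1 to compound 4 (1.03 log units; beyond the scatter)). No outside data bear on these steps.

From the compounds shown here alone, the fluorine and the six-membered non-aromatic ring enter together, so the share of each stays open. Also open, going by these compounds, is how an amine, a carboxylic acid or a longer chain at this place would compare.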